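A Chlorinated Acid Analogue in a Ketone Series

The source may hold more compounds than are shown below. What is called first, only, known or untested is meant among the compounds shown, and "the series" means these compounds.

Compound 1 `COC(=O)c1ccc(OCCCCOc2ccc(C(=O)CC3CCCC3)c(O)c2C)cc1` in an assay on HEK293 cells for positive allosteric modulation of metabotropic glutamate receptor 3 (Rattus norvegicus), read by thallium flux, with a stated time of 2.5 min (on this read-out higher numbers stand for an effect only at larger amounts of compound and lower numbers for an effect already at smaller amounts), gives "not determined" (no result reported).
Compound 2 `COC(=O)c1ccc(OCCCCOc2ccc(C(=O)CC3CCCC3)c(C)c2C)cc1` in this assay gives "not determined" (no result reported).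
Compound 3 `COc1ccc(C(=O)O)cc1OCCCCOc1ccc(C(=O)C(C)C)c(O)c1C` in this assay gives 588 nM.

Compound 2 therefore stands without a single number in this assay, and compound 1 is in the same position, so compound 3 alone supplies a measured value. Compound 4 `Cc1c(OCCCCOc2ccc(C(=O)O)c(Cl)c2)ccc(C(=O)CC2CCCC2)c1C` differs from compound 2 by 4-carboxy-3-chlorophenyl in place of 4-(methoxycarbonyl)phenyl on an oxygen on a saturated carbon. Going by the values given here, no step between measured compounds is available, so the size and direction of this change cannot be set against any measured pair; what is expected rests only on compound 3, which in this assay gives 588 nM. On that basis compound 4 is estimated to give 800 nM in this assay, with an expected range from 150 nM to 4000 nM.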

Compound 4, half-maximal effective concentration: > 10000 nM
Compound 4 was reported as a limit (the forecaster's own chance of this, stated with the estimate: 30%); middle value at least 12-fold (1.09 log units) away from the limit.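

In this assay compound 4 gives > 10000 nM, which is a limit and not a number. With compound 2 also lacking a single value, no step can be read between them. The compounds shown leave open what replacing 4-(methoxycarbonyl)phenyl with 4-carboxy-3-chlorophenyl does on its own.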